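This account rests on a few compounds, and the source may have more. Where it says the series, first, only, none or still open, it means among the compounds named here.

Series notes. Compound 1 `COc1ccc(-c2cc(=O)oc3ccc(F)cc23)cc1O` and compound 2 `COc1ccc(-c2cc(=O)oc3ccccc23)cc1O` share one core; in a physicochemical assay for solubility, in phosphate buffer, with a stated time of 2 h, at pH 7.4 (on this read-out higher numbers stand for higher solubility and lower numbers for lower solubility), compound 1 gives 80000 nM and compound 2 gives 160000 nM. The change between them, (hydrogen in place of fluoro on an aromatic carbon), gave a 2.0-fold higher number from compound 1 to compound 2 (0.30 log units; within the scatter). Compound 3 `COc1ccc(-c2cc(=O)oc3ccc(F)cc23)cn1` carries a different core; the difference between the two cores is not broken down here. In this assay compound 3 gives 80000 nM, level with compound 1. Compound 4 `COc1ccc(-c2cc(=O)oc3ccccc23)cn1` is not yet measured; it stands to compound 3 as compound 2 stands to compound 1, the same change, (hydrogen in place of fluoro on an aromatic carbon), at the same place. For compound 4 the step from compound 3 is expected to be about a 2.0-fold higher number from compound 3 to compound 4 (0.30 log units; within the scatter), resting on a 2.0-fold higher number from compound 1 to compound 2 (0.30 log units; within the scatter) in this assay. The estimate for compound 4 is 160000 nM, expected to lie between 80000 nM and 320000 nM.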

Compound 4, solubility: 80000 nM
The estimate for compound 4 lay 2.0-fold (0.30 log units) above the measured number; measured number inside the range.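

In this assay, hydrogen in place of fluoro on an aromatic carbon gives no change at the digits printed from compound 3 to compound 4 (within the scatter) on the core of compound 3 and a 2.0-fold higher number from compound 1 to compound 2 (0.30 log units; within the scatter) on the core of compound 1, so on both cores the step stays within the scatter. This shows that the change leaves no readable step on either core, but it does not show that the two cores respond alike or differently, and one pair per core cannot fix a step size to carry over. No measurement is at hand that bears on the reason for these numbers.

Open, from the compounds shown here alone, is how either core would read with a larger group at the same aromatic carbon, such as an amine or a carboxylic acid. Also open, going by these compounds, is whether any such step would carry from one core to the other.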